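Replacing sec-butyl with a longer protected chain on the shared core

A few compounds are considered here, and "the series" means these few. Any claim that something is new, unique, unknown or untested is made for them only; others in the source may bear on it.

Measured so far:
compound 1, `N=C(N)NCCC[C@H](NC(=O)CN(c1nc(Cl)nc2c1ncn2C1CCCCO1)C1CC1)C(=O)OCc1ccccc1`: 61.6%
compound 2, `O=C(CN(c1nc(Cl)nc2c1ncn2C1CCCCO1)C1CC1)NCC(=O)OCc1ccccc1`: 25.9%
compound 3, `CC[C@H](C)[C@H](NC(=O)CN(c1nc(Cl)nc2c1ncn2C1CCCCO1)C1CC1)C(=O)OCc1ccccc1`: 22.6%

All three compounds were tested in a functional assay on the whole organism with Mus musculus as the target, with a stated time of 90 min, at a dose of 25 umol/kg by the oral route; on this read-out higher numbers stand for a stronger effect at the one dose given and lower numbers for a weaker effect. Compound 3 gives the lowest number of the three; compound 2 sits within the usual scatter of it, while compound 1 stands well above both.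

Compound 4, `CC(C)(C)OC(=O)NCCCC[C@H](NC(=O)CN(c1nc(Cl)nc2c1ncn2C1CCCCO1)C1CC1)C(=O)OCc1ccccc1`, has not yet been measured. It differs from compound 3 in one place: 4-((tert-butoxycarbonyl)amino)butyl in place of sec-butyl on a saturated chain carbon bound to an amide-type nitrogen and a carbonyl carbon

For the measured compounds named here, two measured steps bear on this change. The step of a number 39 percentage points lower from compound 1 to compound 3 (beyond the scatter) shows that a group rich in nitrogen at this carbon went with a far higher number than sec-butyl, and the step of a number 3.3 percentage points lower from compound 2 to compound 3 (within the scatter) shows that sec-butyl and hydrogen are indistinguishable here. Going by the values given here, compound 4 brings back a chain carrying a nitrogen, a hydrogen-bond donor and two acceptors at the same carbon, yet that chain is not the one found in compound 1. A rise is therefore expected, but a smaller one than a number 39 percentage points lower from compound 1 to compound 3 (beyond the scatter) in reverse, because compound 1 alone, with 61.6%, supports the high value and its group is not the one entering.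

The expected step is a number 13.4 percentage points higher from compound 3 to compound 4 (beyond the scatter). Compound 4 is estimated at 36%, with a range from 15% to 58%.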

Compound 4, a percentage reported as activity, at one dose (the size of the read-out at that dose, not a potency): 32.9%
For compound 4 the middle estimate is 3.1 percentage points above the measured one; low and high end bracket the measured number.
By their numbers in this assay, from the lowest: compounds 3, 2 and 4 (each within the scatter of the next, the first and the last beyond it); then compound 1.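

In this assay, putting 4-((tert-butoxycarbonyl)amino)butyl in place of sec-butyl on this saturated chain carbon gives a number 10.3 percentage points higher from compound 3 to compound 4 (beyond the scatter) and so shows that this carbon accepts a much larger chain without loss of the read-out. Set against hydrogen at the same carbon, the chain gives a number 7 percentage points higher from compound 2 to compound 4 (within the scatter) and so cannot be told apart from having no side chain at all, which makes the gain over sec-butyl a modest one. The step of a number 28.7 percentage points lower from compound 1 to compound 4 (beyond the scatter) adds something the first three compounds could not show: a chain carrying a nitrogen is not enough by itself to reach the level of compound 1, and among the compounds shown, that high number stays with the group of compound 1 alone.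

Nothing measured here explains these differences between the groups. On these data alone, it remains open whether the free amine, left on the same butyl chain once the tert-butoxycarbonyl group is gone, would stay level with compound 4 or come closer to compound 1.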